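Chloropyrazole in Place of the Oxazolidinone Amide Substituent

The source may report more compounds than this note shows. Statements on the series, on what has been measured and on what is new or still open speak of the compounds shown alone.

The three measured compounds share one core and differ only in the group on the saturated chain carbon bound to the carbonyl carbon. In a functional assay on Venous blood for antagonist activity at C-X-C chemokine receptor type 3 (Homo sapiens), read by flow cytometry, with a stated time of 30 min, in the presence of a further agent that is not named here (on this read-out higher numbers stand for weaker inhibition and lower numbers for stronger inhibition), compound 1 `Cc1nn(CC(=O)N2CCN(c3sc(C(F)(F)F)nc3-c3nc4ccccc4[nH]3)C[C@H]2C)cc1CN(C)C` gives 330 nM, compound 3 `Cc1nc(C)n(CC(=O)N2CCN(c3sc(C(F)(F)F)nc3-c3nc4ccc(C(C)(C)O)c(F)c4[nH]3)C[C@H]2C)n1` gives 628 nM, and compound 2 `C[C@@H]1CN(c2sc(C(F)(F)F)nc2-c2nc3ccccc3[nH]2)CCN1C(=O)CN1C(=O)OC[C@@H]1c1ccccc1` gives 1380 nM, the highest of the three numbers, beyond the scatter from both others.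

Compound 4 `C[C@@H]1CN(c2sc(C(F)(F)F)nc2-c2nc3ccccc3[nH]2)CCN1C(=O)Cn1cc(Cl)cn1` changes compound 2 at the same position: 4-chloro-1H-pyrazol-1-yl in place of 2-oxo-4-phenyl-1,3-oxazolidin-3-yl on a saturated chain carbon bound to a carbonyl carbon. Within the data shown here, the one measured step that bears on this position is a 4.2-fold higher number from compound 1 to compound 2 (0.62 log units; beyond the scatter), in which a nitrogen-linked five-membered aromatic ring gave way to the oxazolidinone and the number rose. Compound 4 reverses that direction by bringing back a nitrogen-linked pyrazolyl, though without the dimethylaminomethyl and methyl groups of compound 1, and the pair of compound 1 and compound 3 shows that different small azoles at this position land within a modest spread of each other.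

Compound 4 is therefore expected to give a lower number than compound 2 in this assay, with the estimated step of a 3.1-fold lower number from compound 2 to compound 4 (0.49 log units; beyond the scatter). The estimate for compound 4 is 450 nM, within a range from 200 nM to 1000 nM.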

Compound 4, half-maximal inhibitory concentration: 251 nM
Compound 4: the middle estimate sits 1.8-fold (0.25 log units) above what was measured; the measured number falls inside the stated range.
By their numbers in this assay, from the lowest: compounds 4, 1 and 3 (each within the scatter of the next, the first and the last beyond it); then compound 2.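

In this assay, 4-chloro-1H-pyrazol-1-yl in place of 2-oxo-4-phenyl-1,3-oxazolidin-3-yl gives a 5.5-fold lower number from compound 2 to compound 4 (0.74 log units; beyond the scatter) in a single change at this position, with fewer heavy atoms entering than leave. Among these compounds, the comparison with the more heavily substituted pyrazolyl group shows something the earlier compounds could not: the dimethylaminomethyl and methyl groups of compound 1 are not required to keep the number at this level, since the change to the chloropyrazole gives a 1.3-fold lower number from compound 1 to compound 4 (0.12 log units; within the scatter) and the two compounds cannot be told apart in this assay. No measurement at hand explains why the oxazolidinone stands apart from these two pyrazolyl groups.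

As far as these compounds go, what the chlorine of compound 4 itself contributes remains open, and a comparison with a bare pyrazolyl, or with a methyl or a nitrile instead of the chlorine, would address it. Also open, from the compounds shown here alone, is whether the phenyl or the oxazolidinone ring sets the number of compound 2, a question that a 2-oxo-1,3-oxazolidin-3-yl group without the phenyl would help to settle.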